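Phenyl for Cyclopentyl on the Sulfonamide of Compound 2

The source may report more compounds than this note shows. Statements on the series, on what has been measured and on what is new or still open speak of the compounds shown alone.

The measured compounds in an assay for inhibition of serine/threonine-protein kinase PLK2 (Homo sapiens), read by FRET and Z'-LYTE, with a stated time of 1 h (a higher number here means a weaker inhibitor, a lower number a stronger inhibitor), are:
compound 1 `CCC1C(=O)N(C)c2cnc(-n3ccc4cc(C(N)=O)ccc43)nc2N1c1ccn(C)n1` — 384 nM
compound 2 `CC[C@@H]1C(=O)N(C)c2cnc(Nc3ccc(S(=O)(=O)NC4CCCC4)cc3)nc2N1C1CCCC1` — 23.9 nM
compound 3 `CC[C@@H]1C(=O)N(C)c2cnc(-n3ccc4cc(C(=O)NC)ccc43)nc2N1C1CCCC1` — 8.6 nM

Compound 2 gives the second highest of the three numbers. Its nearest neighbour is compound 3, whose number is lower, beyond the scatter; the furthest is compound 1, whose number is higher, also beyond the scatter. Compound 3 thus shows the lowest number in this set, compound 1 the highest.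

Compound 4 `CC[C@@H]1C(=O)N(C)c2cnc(Nc3ccc(S(=O)(=O)Nc4ccccc4)cc3)nc2N1C1CCCC1` has not been measured. It differs from compound 2 in one place: phenyl in place of cyclopentyl on a sulfonamide nitrogen. Among the compounds with values here, no measured pair shows this change, so its effect is not known from the data. The step expected from compound 2 to compound 4 in this assay is a 1.3-fold higher number from compound 2 to compound 4 (0.10 log units; within the scatter), a small shift that may well stay within the scatter, in either direction. The estimate for compound 4 in this assay is 30 nM, with a range from 10 nM to 90 nM.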

Compound 4, half-maximal inhibitory concentration: 54.4 nM
Compound 4: middle estimate off by 1.8-fold (0.26 log units), on the low side, and the stated range covers the measured number.
By their numbers in this assay, from the lowest: compound 3; then compound 2; then compound 4; then compound 1.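

In this assay, the group on the sulfonamide nitrogen proves to matter: phenyl in place of cyclopentyl gives a 2.3-fold higher number from compound 2 to compound 4 (0.36 log units; beyond the scatter), a modest step but one beyond the scatter. Within the data shown here, this is the first single-place comparison in the set, and it shows that this position accepts an aromatic ring in place of a non-aromatic one with a weaker number, while inhibition stays clearly measurable. Nothing available explains why the number rises with this change.

A single pair cannot separate the change from five-membered to six-membered ring from the change from non-aromatic to aromatic, and cyclohexyl on the same nitrogen would pull these two apart. From the compounds shown here alone, how a much smaller group such as methyl, or a phenyl ring carrying a carboxylic acid, would fare at this position also remains open.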